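This account rests on a few compounds, and the source may have more. Where it says the series, first, only, none or still open, it means among the compounds named here.

Compound 1 `COC(=O)c1c(-c2ccc([N+](=O)[O-])cc2)oc2ccccc2c1=O` and compound 2 `COC(=O)c1c(-c2ccc(O)cc2)oc2ccccc2c1=O` are built on the same core and differ in a single change: hydroxy in place of nitro on an aromatic carbon. In a functional assay on A549 cells (Homo sapiens) for cytotoxicity, read by MTT assay, with a stated time of 6 days (on this read-out lower numbers stand for an effect already at smaller amounts and higher numbers for an effect only at larger amounts of compound), compound 1 gives > 25 ug/mL, which is a limit of the assay and not a number. In this assay compound 2 gives > 25 ug/mL, again a limit rather than a number. The step that the two limits leave unreadable from compound 1 to compound 2 therefore cannot be sized, because of the limit of > 25 ug/mL in this assay, at which 3 of the 3 values shown sit. Compound 3 `COc1ccc2oc(-c3ccc([N+](=O)[O-])cc3)c(C(=O)O)c(=O)c2c1` rests on a different core; the difference between the two cores is not broken down here. In this assay compound 3 gives > 25 ug/mL, once more a limit and not a number. Compound 4 `COc1ccc2oc(-c3ccc(O)cc3)c(C(=O)O)c(=O)c2c1` stands to compound 3 as compound 2 stands to compound 1: hydroxy in place of nitro on an aromatic carbon. The place of the change is described in the same words for both pairs, so it is the same change. The expected size of the step is a step that the limit leaves unreadable from compound 3 to compound 4, and that expectation rests on (the limit of > 25 ug/mL in this assay, at which 3 of the 3 values shown sit). Compound 4 is accordingly estimated at 40 ug/mL, within a range from 25 ug/mL to 100 ug/mL. The measurement itself will show whether this holds.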

Compound 4, concentration for half-maximal effect: > 25 ug/mL
Compound 4: only a limit was reported; the forecaster's own chance of this, stated with the estimate: 85%; the middle value lies beyond the limit too.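

In this assay compound 4 gives > 25 ug/mL, a limit and not a number. No size can be read for the step from nitro to hydroxy between compound 3 and compound 4, because: the limit of > 25 ug/mL in this assay, at which 4 of the 4 values shown sit. The compounds shown leave open whether this change alters the effect on either core, and at what amounts any of the four compounds would act.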